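The compounds below may be only part of what the source reports. "The series", "measured", "known", "first", "only" and "open" are said of these compounds alone.

Measured compounds, each with its result in a toxicity assay on MDCK cells (Canis lupus familiaris) for cytotoxicity, read by crystal violet staining, with a stated time of 48 h; a lower number here means that less compound is tolerated, a higher number that more compound is tolerated:

Compound 1 `Cc1ccc2[nH]c(=O)c(CN(Cc3ccc(N(C)C)cc3)Cc3ccc(C(C)(C)C)cc3)cc2c1` — a limit of the assay, > 5000 nM
Compound 2 `Cc1ccc2[nH]c(=O)c(CN(Cc3ccc(C#N)cc3)Cc3ccc(C(C)(C)C)cc3)cc2c1` — a limit of the assay, > 5000 nM
Compound 3 `Cc1ccc2[nH]c(=O)c(CN(Cc3ccc(C(C)(C)C)cc3)[C@@H](C)c3ccc(F)cc3)cc2c1` — a limit of the assay, > 5000 nM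

Compound 1 does not stand at a number in this assay but at a limit, which is where the other two values sit as well (the limit of > 5000 nM in this assay, at which 3 of the 3 values shown sit). For that reason none of the steps between the measured compounds can be read: a step that the two limits leave unreadable from compound 1 to compound 2, a step that the two limits leave unreadable from compound 1 to compound 3 and a step that the two limits leave unreadable from compound 2 to compound 3 are all unreadable in size.

Compound 4 `COc1ccc2[nH]c(=O)c(CN(Cc3ccc(N(C)C)cc3)Cc3ccc(C(C)(C)C)cc3)cc2c1` differs from compound 1 in one place: methoxy in place of methyl on an aromatic carbon. For the measured compounds named here, no measured step touches that position of the shared core; the measured steps all concern the groups on the amine nitrogen, and even those could not be sized. What the three measured compounds do show is that none of them reached a readable value in this assay.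

On that basis compound 4 is expected to behave like compound 1 and again sit at the limit, so the step that the limit leaves unreadable from compound 1 to compound 4 is estimated as no step beyond the scatter. The estimate for compound 4 is 8000 nM, with a range from 3000 nM to 30000 nM.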

Compound 4, half-maximal cytotoxic concentration: 8500 nM
The estimate for compound 4 lay 1.1-fold (0.03 log units) below the measured number; the measured number falls inside the stated range.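

No size can be read for the step between compound 1 and compound 4, because compound 1 stands at a limit and not at a number: the limit of > 5000 nM in this assay, at which 3 of the 4 values shown sit. Going by these compounds, whether methoxy in place of methyl on the shared core changes how much compound the cells tolerate stays open.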